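Aromatic substituent series: from compound 3 to compound 4

The source may hold more compounds than are shown below. What is called first, only, known or untested is meant among the compounds shown, and "the series" means these compounds.

Measured so far in a functional assay on HepG2 cells (Homo sapiens) for antiproliferative activity, read by XTT assay, with a stated time of 72 h; a higher number here means a weaker inhibitor, a lower number a stronger inhibitor:
compound 1, `COc1ncnc2c1c(-c1cccs1)cn2[C@@H]1O[C@H](CO)[C@@H](O)[C@H]1O`, gives 13900 nM.
compound 2, `Cc1ncnc2c1c(-c1cccs1)cn2[C@@H]1O[C@H](CO)[C@@H](O)[C@H]1O`, gives a limit of > 15000 nM.
compound 3, `CNc1ncnc2c1c(-c1cccs1)cn2[C@@H]1O[C@H](CO)[C@@H](O)[C@H]1O`, gives a limit of > 20000 nM.

Compound 3 stands at the weak end of what is shown: its result is a limit and no number, as stated in the limit of > 20000 nM in this assay, at which 1 of the 3 values shown sits. Compound 2 likewise sits at a limit, (the limit of > 15000 nM in this assay, at which 1 of the 3 values shown sits). Only compound 1 gives a number, and it is itself a weak one in this assay.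

Compound 4, `CN(C)c1ncnc2c1c(-c1cccs1)cn2[C@@H]1O[C@H](CO)[C@@H](O)[C@H]1O`, differs from compound 3 by methyl in place of hydrogen on a nitrogen on an aromatic ring, the change reading methylamino to dimethylamino.

Among the compounds with values here, no measured step touches a methyl on this nitrogen. The step nearest in kind is an at least 1.4-fold higher number from compound 1 to compound 3 (0.15 log units; that floor lies within the scatter), which only sets a floor, and a step that the two limits leave unreadable from compound 2 to compound 3, which the two limits leave unreadable. an at least 1.0-fold higher number from compound 1 to compound 2 (0.03 log units; that floor lies within the scatter) shows that no change at this aromatic carbon so far has moved the number downward beyond the scatter. On this basis no step beyond the scatter is expected from compound 3 to compound 4, and a limit is again the likeliest outcome.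

Compound 4 is therefore expected to give about 25000 nM, within a range of 10000 nM to 60000 nM, which means an expected step that the limit leaves unreadable from compound 3 to compound 4.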

Compound 4, half-maximal inhibitory concentration: > 20000 nM
Compound 4: no number, only a limit; the forecaster's own chance of this, stated with the estimate: 70%; the middle value is on the limit's open side.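

In this assay compound 4 gives > 20000 nM, which is a limit and not a number. Methyl in place of hydrogen on this nitrogen therefore does not bring the series back to a numeric value, and dimethylamino joins methylamino and methyl in giving only a limit, leaving methoxy in compound 1 as the only group here with a number: the limit of > 20000 nM in this assay, at which 2 of the 4 values shown sit. Within the data shown here, the one readable new step is an at least 1.4-fold higher number from compound 1 to compound 4 (0.15 log units; that floor lies within the scatter), so it sets only a floor that does not separate dimethylamino from methoxy, while the steps linking compound 4 to compound 2 and compound 3 cannot be read.

As far as these compounds go, the true size of the methyl step on this nitrogen stays open, since neither end of it is a number in this assay. Also open, from the compounds shown here alone, is whether a free amino group, a cyclic amine such as pyrrolidine or a longer alkoxy chain such as ethoxy on this aromatic carbon would give a numeric value, and how that value would compare with compound 1.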